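Dichlorophenyl swap on two dimethoxy cores in fibroblast toxicity

A few compounds are considered here, and "the series" means these few. Any claim that something is new, unique, unknown or untested is made for them only; others in the source may bear on it.

Measured compounds:
compound 1, `COc1cccc(/C=C2\CCC/C(=C\c3ccc(Cl)c(Cl)c3)C2=O)c1OC`: 25500 nM
compound 2, `COc1cccc(/C=C2\CCC/C(=C\c3cc(Cl)cc(Cl)c3)C2=O)c1OC`: 21600 nM
compound 3, `COc1ccc(/C=C2\CCC/C(=C\c3ccc(Cl)c(Cl)c3)C2=O)cc1OC`: 10100 nM

Three compounds were tested in an ADME assay on NHDF cells (Homo sapiens) for cytotoxicity, read by MTT assay, with a stated time of 72 h; on this read-out higher numbers stand for weaker inhibition and lower numbers for stronger inhibition. Compound 1 gave 25500 nM and compound 2 gave 21600 nM in this assay; the change between them, (3,5-dichlorophenyl in place of 3,4-dichlorophenyl on a double-bonded chain carbon bound to a double-bonded ring carbon), produced a 1.2-fold lower number from compound 1 to compound 2 (0.07 log units; within the scatter). Compound 3, which carries a different core, gave 10100 nM; how its core differs from that of compound 1 is not broken down here. Compound 4, `COc1ccc(/C=C2\CCC/C(=C\c3cc(Cl)cc(Cl)c3)C2=O)cc1OC`, has not yet been measured. It arises from compound 3 by the same change, (3,5-dichlorophenyl in place of 3,4-dichlorophenyl on a double-bonded chain carbon bound to a double-bonded ring carbon). Since that change gave a 1.2-fold lower number from compound 1 to compound 2 (0.07 log units; within the scatter), a similarly small step is expected here, estimated as a 1.2-fold lower number from compound 3 to compound 4 (0.07 log units; within the scatter). Compound 4 is therefore expected to give about 8500 nM in this assay, likely between 4000 nM and 18000 nM.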

Compound 4, half-maximal inhibitory concentration: 8300 nM
Compound 4: middle estimate off by 1.0-fold (0.01 log units), on the high side; the range from low to high includes it.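

In this assay, putting 3,5-dichlorophenyl in place of 3,4-dichlorophenyl on the second core gave a 1.2-fold lower number from compound 3 to compound 4 (0.09 log units; within the scatter), and this step matches the one seen on the first core: the same change on two cores in this assay, a 1.2-fold lower number (0.07 log units; within the scatter) from compound 1 to compound 2 and a 1.2-fold lower number (0.09 log units; within the scatter) from compound 3 to compound 4, 1.0-fold (0.01 log units) apart, within the scatter of two such steps. On these two cores, then, the change carries over as a step within the scatter, and moving the chlorine makes no readable difference to the number on either core. Within the data shown here, this does not show that the step would stay as small on a third core, since only two cores enter the comparison, and it gives no reason for the result.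

The compounds shown leave open how the number would respond if an amine or a carboxylic acid stood on that phenyl ring in place of the chlorines.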